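Cyclopentyl in Place of Neopentyl on the Ring Nitrogen

The source may report more compounds than this note shows. Statements on the series, on what has been measured and on what is new or still open speak of the compounds shown alone.

Within the data shown here, compound 3 `Cc1ccc(S(=O)(=O)N2C=CNC(=O)[C@H]2CC(=O)N[C@H]2CCN(CC(C)(C)C)CC2(C)C)cc1` gives 1.38 nM in an in vitro functional assay on cells for antagonist activity at B1 bradykinin receptor (Homo sapiens), read by luminescence and calcium flux, with a stated time of 2 h (on this read-out lower numbers stand for stronger inhibition and higher numbers for weaker inhibition), the highest of the three numbers measured so far. Compound 1 `CCCN1CC[C@H](NC(=O)C[C@@H]2C(=O)NC=CN2S(=O)(=O)c2ccc(C)cc2)C(C)(C)C1` gives 0.51 nM and compound 2 `Cc1ccc(S(=O)(=O)N2C=CNC(=O)[C@H]2CC(=O)N[C@H]2CCN(CC(C)C)CC2(C)C)cc1` gives 0.86 nM. The steps of a 2.7-fold higher number from compound 1 to compound 3 (0.43 log units; beyond the scatter) and a 1.6-fold higher number from compound 2 to compound 3 (0.21 log units; within the scatter) show how enlarging the group on the amine nitrogen has moved the number, while a 1.7-fold higher number from compound 1 to compound 2 (0.23 log units; within the scatter) stays within the scatter. Compound 4 `Cc1ccc(S(=O)(=O)N2C=CNC(=O)[C@H]2CC(=O)N[C@H]2CCN(C3CCCC3)CC2(C)C)cc1` differs from compound 3 by cyclopentyl in place of neopentyl on an amine nitrogen in a ring. Among the measured compounds shown here, no measured step exchanges a branched chain for a ring of equal size, so the record only shows that changes at this nitrogen have stayed small. Compound 4 is therefore expected at 1.2 nM, within 0.4 nM to 4 nM, an expected step of a 1.2-fold lower number from compound 3 to compound 4 (0.06 log units; within the scatter) that does not go beyond the scatter.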

Compound 4, half-maximal inhibitory concentration: 0.247 nM
The estimate for compound 4 lay 4.9-fold (0.69 log units) above the measured number; measured number outside the range, below it.
By their numbers in this assay, from the lowest: compound 4; then compounds 1, 2 and 3 (each within the scatter of the next, the first and the last beyond it).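

With the count of five carbons unchanged, replacing neopentyl with cyclopentyl on the amine nitrogen gives a 5.6-fold lower number from compound 3 to compound 4 (0.75 log units; beyond the scatter) in this assay and so shows that a ring here, not only the size of the group, bears on the number. Cyclopentyl also stands beyond the scatter against the other chains, with a 3.5-fold lower number from compound 2 to compound 4 (0.54 log units; beyond the scatter) and a 2.1-fold lower number from compound 1 to compound 4 (0.31 log units; beyond the scatter), which leaves compound 4 the most potent of the four. Nothing measured here accounts for this difference.

From the compounds shown here alone, whether cyclobutyl, cyclohexyl or a tetrahydropyranyl ring would behave the same on this nitrogen remains open.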